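This account rests on a few compounds, and the source may have more. Where it says the series, first, only, none or still open, it means among the compounds named here.

Compound 1 `CCC(C)CC(=O)OCC(C)(C)CC1=C(O)C(=O)c2ccccc2C1=O` is one of three esters that share a core and differ only in the acyl chain. In an ADME assay on Vero cells (Chlorocebus sabaeus) for cytotoxicity, read by MTT assay (a higher number here means a weaker inhibitor, a lower number a stronger inhibitor), compound 1 gives 2300 nM, the highest of the two plain numbers shown, and it stands a step above compound 3 `CCCCCCC(C)C(=O)OCC(C)(C)CC1=C(O)C(=O)c2ccccc2C1=O`. Compound 3 gives 450 nM, a step of a 5.1-fold lower number from compound 1 to compound 3 (0.71 log units; beyond the scatter). Compound 2 `CCCCCCCC(=O)OCC(C)(C)CC1=C(O)C(=O)c2ccccc2C1=O` is recorded only as a limit of the assay: compound 2 gives > 258000 nM. The step of an at least 110-fold higher number from compound 1 to compound 2 (2.04 log units; beyond the scatter) is thus large, and so is an at least 570-fold lower number from compound 2 to compound 3 (2.75 log units; beyond the scatter).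

The unmeasured compound 4 `CCCCCCCCC(=O)OCC(C)(C)CC1=C(O)C(=O)c2ccccc2C1=O` is obtained from compound 1 by the change (heptyl in place of sec-butyl on a saturated chain carbon bound to a carbonyl carbon). The measured step that bears most directly on it is an at least 110-fold higher number from compound 1 to compound 2 (2.04 log units; beyond the scatter), where hexyl on a saturated chain carbon bound to a carbonyl carbon took the number to the limit (the limit of > 258000 nM in this assay, at which 1 of the 3 values shown sits). Compound 4 carries heptyl on the same carbon, so a large rise is expected, and the result may again come back as a limit rather than a number. The expected step is an 87-fold higher number from compound 1 to compound 4 (1.94 log units; beyond the scatter). Compound 4 is estimated at 200000 nM, within 20000 nM to 400000 nM.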

Compound 4, half-maximal inhibitory concentration: 150000 nM
Beside the measured number, compound 4's estimate is 1.3-fold (0.12 log units) above it; measured number inside the range.
By their numbers in this assay, from the lowest: compound 3; then compound 1; then compound 4. At a limit, above all of these: compound 2.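

With heptyl on a saturated chain carbon bound to a carbonyl carbon, a 65-fold higher number from compound 1 to compound 4 (1.81 log units; beyond the scatter) gives this change a measured size in this assay, whereas the earlier rise to compound 2 ended at a limit. The contrast with the 1-methylheptyl chain is just as large, with octyl in place of 1-methylheptyl on a carbonyl carbon giving a 330-fold higher number from compound 3 to compound 4 (2.52 log units; beyond the scatter), so the low number of compound 3 does not carry over to the octyl chain of compound 4. Among these compounds, the remaining step, an at least 1.7-fold lower number from compound 2 to compound 4 (0.23 log units; that floor lies within the scatter), rests on a limit and not on a number, and it fixes no order within that pair: the limit of > 258000 nM in this assay, at which 1 of the 4 values shown sits.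

The compounds shown do not settle whether a methyl branch by itself accounts for the lower numbers of compound 1 and compound 3, since the branch sits at a different place on each chain and the chains differ in name as well. They also leave open how a longer chain such as decyl would read in this assay, or a chain ending in an amine or a carboxylic acid.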